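This account rests on a few compounds, and the source may have more. Where it says the series, first, only, none or still open, it means among the compounds named here.

Measured in a functional assay on A549 cells (Homo sapiens) for cytotoxicity, read by MTT assay, with a stated time of 24 h, tested at 40 uM; on this read-out higher numbers stand for a weaker effect at the one concentration tested and lower numbers for a stronger effect:
Compound 1 `CCCCCOC(=O)CCC(=O)N1CCN(CCCOc2cc3c(Nc4ccc(F)c(Cl)c4)ncnc3cc2OC)CC1`: 63.6%.
Compound 2 `CCCCCCOC(=O)CCC(=O)N1CCN(CCCOc2cc3c(Nc4ccc(F)c(Cl)c4)ncnc3cc2OC)CC1`: 74.2%.
Compound 3 `CCCCCCCCCCCOC(=O)CCC(=O)N1CCN(CCCOc2cc3c(Nc4ccc(F)c(Cl)c4)ncnc3cc2OC)CC1`: 12%.

Compound 3 gives the lowest number of the three, beyond the scatter from both compound 1 and compound 2. Compound 4 `CCCCCCCCCCCCOC(=O)CCC(=O)N1CCN(CCCOc2cc3c(Nc4ccc(F)c(Cl)c4)ncnc3cc2OC)CC1` differs from compound 3 by methyl in place of hydrogen on a saturated chain carbon, ten or more bonds along the chain from an oxygen next to a carbonyl group. Among the compounds with values here, the steps that bear on this are the chain extensions already seen: a number 10.6 percentage points higher from compound 1 to compound 2 (beyond the scatter), a number 51.6 percentage points lower from compound 1 to compound 3 (beyond the scatter) and a number 62.2 percentage points lower from compound 2 to compound 3 (beyond the scatter). A single methyl added to an already long chain is a much smaller change than those, and the number for compound 3 leaves little room to fall further. A step within the scatter, or a small one downward, is expected in this assay, that is a number 2 percentage points lower from compound 3 to compound 4 (within the scatter). Compound 4 is estimated at 10%, between 2% and 30%.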

Compound 4, a percentage reported as activity, at one concentration (the size of the read-out at that concentration, not a potency): 5.7%
Compound 4: middle estimate off by 4.3 percentage points, on the high side, within the range that was stated.
By their numbers in this assay, from the lowest: compounds 4 and 3 (each within the scatter of the next); then compound 1; then compound 2.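

In this assay, methyl in place of hydrogen on a saturated chain carbon, ten or more bonds along the chain from an oxygen next to a carbonyl group, gives a number 6.3 percentage points lower from compound 3 to compound 4 (within the scatter), so the long-chain pair reads level. Compound 4 keeps the large gap to the shorter chains, with a number 68.5 percentage points lower from compound 2 to compound 4 (beyond the scatter) and a number 57.9 percentage points lower from compound 1 to compound 4 (beyond the scatter). The same added methyl does not read alike at the two chain lengths: the same change on two cores in this assay, a number 10.6 percentage points higher (beyond the scatter) from compound 1 to compound 2 and a number 6.3 percentage points lower (within the scatter) from compound 3 to compound 4, 16.9 percentage points apart, beyond the scatter of two such steps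

Open, as far as these compounds go, is where the number drops along the chain lengths between compound 2 and compound 3. Also open, from the compounds shown here alone, is how a longer chain, or a carboxylic acid or amine at the chain end, would read.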